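The compounds below may be only part of what the source reports. "The series", "measured", "known", "first", "only" and "open" are said of these compounds alone.

Three compounds share one core, differing only in the group attached to an aromatic carbon of the five-membered ring. Compound 1 `O=C1C[C@H](OCc2cc(-c3ccccc3)no2)[C@H]2CO[C@@H]1O2` gives 16900 nM in a functional assay on HT-29 cells (Homo sapiens) for cytotoxicity, read by MTT assay, with a stated time of 48 h; on this read-out higher numbers stand for weaker inhibition and lower numbers for stronger inhibition. Compound 2 `O=C1C[C@H](OCc2cc(/C=C/c3ccccc3)no2)[C@H]2CO[C@@H]1O2` gives 13700 nM, and compound 3 `O=C1C[C@H](OCc2cc(-c3ccc(Cl)cc3)no2)[C@H]2CO[C@@H]1O2` gives 14500 nM. The steps are a 1.2-fold lower number from compound 1 to compound 2 (0.09 log units; within the scatter), a 1.2-fold lower number from compound 1 to compound 3 (0.07 log units; within the scatter) and a 1.1-fold higher number from compound 2 to compound 3 (0.02 log units; within the scatter), so compound 3 sits within the scatter of both others. Compound 4 `O=C1C[C@H](OCc2cc(C3CCCCC3)no2)[C@H]2CO[C@@H]1O2` changes the same place: cyclohexyl in place of 4-chlorophenyl on an aromatic carbon. Among the compounds with values here, every change at this position so far, whether a chloro added or the phenyl exchanged for a 2-phenylethenyl, has left the number within the scatter, so no step beyond the scatter is expected here either, giving an estimated 1.0-fold higher number from compound 3 to compound 4 (0.01 log units; within the scatter). Compound 4 is therefore expected to give about 15000 nM, between 7000 nM and 33000 nM.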

Compound 4, half-maximal inhibitory concentration: 9000 nM
For compound 4 the middle estimate is 1.7-fold (0.22 log units) above the measured one, within the range that was stated.
By their numbers in this assay, from the lowest: compounds 4, 2, 3 and 1 (each within the scatter of the next).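

Unlike compound 1, compound 2 and compound 3, compound 4 carries a non-aromatic ring of carbon only on this aromatic carbon, and in this assay every step to it lies within the scatter: a 1.6-fold lower number from compound 3 to compound 4 (0.21 log units; within the scatter), a 1.5-fold lower number from compound 2 to compound 4 (0.18 log units; within the scatter) and a 1.9-fold lower number from compound 1 to compound 4 (0.27 log units; within the scatter). Among these four compounds, then, an aromatic ring at this place is not needed for a number in this range. Nothing measured here explains why these groups read alike. Still open, on these data alone, is whether an amine, a carboxylic acid or a longer chain at this place would give a step beyond the scatter.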